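From cyclopentyl amide to piperidine amide in microsomal clearance

A few compounds are considered here, and "the series" means these few. Any claim that something is new, unique, unknown or untested is made for them only; others in the source may bear on it.

Measured in an in vitro ADME assay on microsomes from liver (Homo sapiens) for pharmacokinetics, read by LC-MS, with a stated time of 10 min, tested at 1 uM; on this read-out lower numbers stand for slow clearance and higher numbers for fast clearance:
compound 1 `CN1C[C@H](C(=O)Nc2ccc(Br)cc2)[C@@H](c2ccc(/C=C/C(=O)Nc3ccccc3N)cc2)C1`: 3 mL/min/kg
compound 2 `Cc1ccc(NC(=O)[C@H]2CN(C)C[C@@H]2c2ccc(/C=C/C(=O)Nc3ccccc3N)cc2)cn1`: 8 mL/min/kg
compound 3 `CN1C[C@H](C(=O)NC2CCCC2)[C@@H](c2ccc(/C=C/C(=O)Nc3ccccc3N)cc2)C1`: 9 mL/min/kg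

Compound 3 sits at the upper end of these numbers, level with compound 2 within the scatter, at a 1.1-fold higher number from compound 2 to compound 3 (0.05 log units; within the scatter). Compound 1 lies clearly lower, with a 3.0-fold higher number from compound 1 to compound 3 (0.48 log units; beyond the scatter).

Compound 4 `CN1C[C@H](C(=O)N2CCCCC2)[C@@H](c2ccc(/C=C/C(=O)Nc3ccccc3N)cc2)C1` has piperidin-1-yl in place of cyclopentylamino on a carbonyl carbon. Going by the values given here, no measured compound carries this group, so the two steps above bear on it only indirectly. Both change the group on an amide-type nitrogen, and they are modest at most. The expected step is a 1.1-fold higher number from compound 3 to compound 4 (0.05 log units; within the scatter), with none expected beyond the scatter. The estimate for compound 4 is 10 mL/min/kg, with an expected range from 4 mL/min/kg to 25 mL/min/kg.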

Compound 4, clearance: 9 mL/min/kg
Compound 4: the middle estimate sits 1.1-fold (0.05 log units) above what was measured, within the range that was stated.
By their numbers in this assay, from the lowest: compound 1; then compounds 2, 3 and 4 (each within the scatter of the next).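

In this assay, piperidin-1-yl, which has no hydrogen-bond donor, replaces cyclopentylamino on the carbonyl carbon with no change at the digits printed from compound 3 to compound 4 (within the scatter), so losing the amide hydrogen here leaves the number unmoved. Against (6-methylpyridin-3-yl)amino the change gives a 1.1-fold higher number from compound 2 to compound 4 (0.05 log units; within the scatter), whereas against (4-bromophenyl)amino it gives a 3.0-fold higher number from compound 1 to compound 4 (0.48 log units; beyond the scatter), leaving compound 1 as the only one of the four set apart. Nothing available explains these results. Going by these compounds, whether morpholin-4-yl or an open-chain diethylamino group on this carbonyl carbon would behave like piperidin-1-yl remains open. So does the effect of a carboxylic acid on the piperidine ring.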